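The source may hold more compounds than are shown below. What is called first, only, known or untested is meant among the compounds shown, and "the series" means these compounds.

In a functional assay on HeLa cells (Homo sapiens) for cytotoxicity, read by MTT assay, with a stated time of 48 h (on this read-out lower numbers stand for an effect already at smaller amounts and higher numbers for an effect only at larger amounts of compound), compound 1 `CO[C@H]1O[C@H](COc2ccc(OC3CCCCC3)cc2)[C@@H](O)[C@H](O)[C@H]1Oc1ccc(OC2CCCCC2)cc1` gives 14000 nM. Compound 2 `CO[C@@H]1O[C@H](COc2ccc(OC3CCCCC3)cc2)[C@@H](O)[C@H](O)[C@H]1Oc1ccc(OC2CCCCC2)cc1` gives 14000 nM in this assay, and compound 3 `CO[C@H]1O[C@H](COc2ccc(OC3CCCCC3)cc2)[C@@H](O)[C@H](O)[C@H]1Oc1ccc(C(C)C)cc1` gives 18000 nM. Compound 1 thus stands level with compound 2, the two together the lowest of the three numbers, and compound 3 is the furthest from it. The step of no change at the digits printed from compound 1 to compound 2 (within the scatter) rests on (the fact that compounds 1 and 2 differ only in the configuration as drawn). The step of a 1.3-fold higher number from compound 1 to compound 3 (0.11 log units; within the scatter) replaces cyclohexyloxy by isopropyl on an aromatic carbon and stays within the scatter.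

Compound 4 `CO[C@H]1O[C@H](COc2ccc(C3CCCCC3)cc2)[C@@H](O)[C@H](O)[C@H]1Oc1ccc(OC2CCCCC2)cc1` has not yet been measured in this assay. It differs from compound 1 in one place: cyclohexyl in place of cyclohexyloxy on an aromatic carbon. For the measured compounds named here, the only measured step that bears on this change is a 1.3-fold higher number from compound 1 to compound 3 (0.11 log units; within the scatter), where cyclohexyloxy also gave way to a group without its oxygen and the number barely moved. A step of about the same small size is therefore expected here, with no shift beyond the scatter in either direction. For compound 4 the expected step is a 1.1-fold higher number from compound 1 to compound 4 (0.03 log units; within the scatter). Compound 4 is estimated at 15000 nM, with a range from 7000 nM to 32000 nM.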

Compound 4, half-maximal effective concentration: 10000 nM
Estimate against measurement, compound 4: 1.5-fold (0.18 log units) above; the measured number falls inside the stated range.
By their numbers in this assay, from the lowest: compounds 4, 1, 2 and 3 (each within the scatter of the next).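

For the compounds shown here, the step, a 1.4-fold lower number from compound 1 to compound 4 (0.15 log units; within the scatter), is the first to touch this cyclohexyloxy group, and it removes only the linking oxygen while the six-membered carbon ring stays in place. In this assay the two numbers cannot be told apart, so at this place on the aromatic ring, the linking oxygen makes no difference that this read-out can resolve. Nothing given here bears on why this swap leaves the number within the scatter.

Still open, on these data alone, is whether a group of a different kind at this place, such as an amine or a carboxylic acid, would move the number beyond the scatter. Also open, as far as these compounds go, is what happens when the cyclohexyloxy groups on both aromatic rings are replaced in the same compound.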